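Replacing 2-(pyrrolidin-1-yl)ethyl with a triazolyl group

The source may hold more compounds than are shown below. What is called first, only, known or untested is meant among the compounds shown, and "the series" means these compounds.

Among the measured compounds shown here, in a functional assay on DU-145 cells (Homo sapiens) for inhibition (a lower number here means a stronger inhibitor of growth, a higher number a weaker inhibitor of growth), compound 2 `C=C1C(=O)O[C@H]2[C@H]1CC/C(COC(=O)NCCN1CCCC1)=C\CC[C@@]1(C)O[C@@H]21` gives 7420 nM, the higher of the two numbers known so far, which makes it the weaker inhibitor of growth of the pair. The other measured compound, compound 1 `C=C1C(=O)O[C@H]2[C@H]1CC/C(COC(=O)N1CCC(F)(F)CC1)=C\CC[C@@]1(C)O[C@@H]21`, gives 2440 nM. Compound 3 `C=C1C(=O)O[C@H]2[C@H]1CC/C(COC(=O)Nc1n[nH]c(SC)n1)=C\CC[C@@]1(C)O[C@@H]21` keeps the shared core and the carbonyl, but carries 5-(methylsulfanyl)-1H-1,2,4-triazol-3-yl in place of 2-(pyrrolidin-1-yl)ethyl on an amide-type nitrogen. For the measured compounds named here, one measured step bears on this change, as it also alters what sits on the carbonyl carbon: a 3.0-fold higher number from compound 1 to compound 2 (0.48 log units; beyond the scatter), modest but beyond the scatter. That step shows that a change in this part of the structure can shift the number in this assay by a modest amount. It offers no direct evidence on a triazole, which neither measured compound carries, so the expectation remains uncertain. A modest move towards a lower number is expected, starting from the high position of compound 2. The expected size of the change is a 3.7-fold lower number from compound 2 to compound 3 (0.57 log units; beyond the scatter). For compound 3 the estimated value is 2000 nM, with an expected range from 500 nM to 7000 nM.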

Compound 3, concentration for 50% growth inhibition: 3490 nM
Beside the measured number, compound 3's estimate is 1.7-fold (0.24 log units) below it; the measured number falls inside the stated range.
By their numbers in this assay, from the lowest: compounds 1 and 3 (each within the scatter of the next); then compound 2.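

Set against compound 2 in this assay, the exchange of 2-(pyrrolidin-1-yl)ethyl for 5-(methylsulfanyl)-1H-1,2,4-triazol-3-yl on the amide-type nitrogen gives a 2.1-fold lower number from compound 2 to compound 3 (0.33 log units; beyond the scatter), showing that this position responds to a change of the group on that nitrogen while the heavy-atom count stays the same and the carbonyl stays in place. The earlier pair left open whether keeping the amide hydrogen goes with the higher number, but compound 3 also keeps it and shows a 1.4-fold higher number from compound 1 to compound 3 (0.16 log units; within the scatter), so among these compounds a (5-(methylsulfanyl)-1H-1,2,4-triazol-3-yl)amino group cannot be told apart from 4,4-difluoropiperidin-1-yl on the carbonyl carbon. Nothing at hand accounts for the size of either step.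

Among the compounds shown, the triazole ring and the methylsulfanyl group occur only together, so their separate shares in the step to compound 3 remain open. Also open, on these data alone, is how the number in this assay would respond to a methoxy group in place of methylsulfanyl on the triazole, or to a phenyl ring on the same nitrogen.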